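Working notes: methoxy in place of fluoro, compound 3

The source may report more compounds than this note shows. Statements on the series, on what has been measured and on what is new or still open speak of the compounds shown alone.

Measured so far:
- compound 1 `O=C(CN1CCN(C(=O)c2ccc(Cl)cc2)CC1)N1CCN(CCCc2c[nH]c3ccc(F)cc23)CC1` gives 44500 nM as its value
- compound 2 `O=C(CN1CCN(C(=O)c2ccc(Br)cc2)CC1)N1CCN(CCCc2c[nH]c3ccc(F)cc23)CC1` gives 60500 nM as its value

Within the data shown here, only two compounds have been measured in an ADME assay on HEK293 cells (Homo sapiens) for cytotoxicity, read by MTT assay, with a stated time of 72 h (on this read-out lower numbers stand for stronger inhibition and higher numbers for weaker inhibition), so far, and compound 1 stands level with compound 2: the single measured step is a 1.4-fold higher number from compound 1 to compound 2 (0.13 log units; within the scatter) and gives no ranking between them.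

The next compound is compound 3 `COc1ccc2[nH]cc(CCCN3CCN(C(=O)CN4CCN(C(=O)c5ccc(Cl)cc5)CC4)CC3)c2c1` and it differs from compound 1 by methoxy in place of fluoro on an aromatic carbon in the shared core, which in words is methoxy in place of fluoro on an aromatic carbon, or 5-fluoro-1H-indol-3-yl to 5-methoxy-1H-indol-3-yl.

Among the measured compounds shown here, the one measured step is bromo in place of chloro on an aromatic carbon, at another place in the structure, so it offers only indirect guidance. For the measured compounds named here, no measured step replaces fluoro, and the data favour no direction. The expected change is a 1.0-fold higher number from compound 1 to compound 3 (0.01 log units; within the scatter) and nothing beyond the scatter is expected. For compound 3 the estimated value is 46000 nM with an expected range from 20000 nM to 100000 nM in this assay.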

Compound 3, half-maximal inhibitory concentration: 117000 nM
Compound 3: the middle estimate sits 2.5-fold (0.41 log units) below what was measured; the measured number lies above the stated range.
By their numbers in this assay, from the lowest: compounds 1, 2 and 3 (each within the scatter of the next, the first and the last beyond it).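

In this assay, among these compounds, going from 5-fluoro-1H-indol-3-yl to 5-methoxy-1H-indol-3-yl gives a 2.6-fold higher number from compound 1 to compound 3 (0.42 log units; beyond the scatter) and is the first step to clear the scatter, while the change at the other site, with a 1.4-fold higher number from compound 1 to compound 2 (0.13 log units; within the scatter), does not. The number at this position of the shared core therefore moves with the substituent, and methoxy reads as the weaker inhibitor of this pair, although the step is modest and rests on one matched pair only. Nothing measured here bears on why this change moves the number.

Still open, from the compounds shown here alone, is whether the same shift would appear with other groups on this aromatic carbon, such as hydroxy, an amine, ethoxy or plain hydrogen, which would show whether methoxy stands alone or belongs to a wider trend. Also open, going by these compounds, is whether the step keeps its size with bromo in place of chloro at the other site, or with a longer chain leading to the core.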